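A Hydroxy-to-Aminomethyl Swap on the Piperidine Side Chain

The source may hold more compounds than are shown below. What is called first, only, known or untested is meant among the compounds shown, and "the series" means these compounds.

Compound 1 `COc1cc2nc(CCc3ccc(F)cc3)nc(N3CCC(CCNS(N)(=O)=O)CC3)c2cc1OC` carries a long arm at one position of its shared core and a sulfamide-terminated chain on the saturated ring; in an assay on cells for inhibition of Ectonucleotide pyrophosphatase/phosphodiesterase family member 1 (Homo sapiens), with a stated time of 60 min (a lower number here means a stronger inhibitor, a higher number a weaker inhibitor), compound 1 gives 366 nM. Compound 2 `COc1cc2ncnc(N3CCC(CCNC(C)=O)CC3)c2cc1OC` keeps the core and the saturated ring but ends its chain in an acetamide; in this assay compound 2 has "not determined" (no result reported). Compound 3 `COc1cc2ncnc(N3CCC(CO)CC3)c2cc1OC` shortens the chain to a single hydroxy-bearing carbon; in this assay compound 3 likewise has "not determined" (no result reported). So compound 3 stands nowhere on the numbers: no value has been reported for it, and the same is true of compound 2, leaving compound 1 as the only compound with a number.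

Compound 4 `COc1cc2ncnc(N3CCC(CCN)CC3)c2cc1OC` is made from compound 3 by a single exchange: aminomethyl in place of hydroxy on a saturated chain carbon bound to a saturated ring carbon. For the measured compounds named here, no step between measured compounds is available to size this change, and compound 3 itself has no number, so no direction can be read from the data; the expectation below rests only on compound 1 being the one measured point, and on compound 4 lacking the long arm that compound 1 carries. Compound 4 is expected to give an inhibition constant of about 3000 nM in this assay, with a plausible range from 500 nM to 20000 nM.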

Compound 4, inhibition constant: 699 nM
Estimate against measurement, compound 4: 4.3-fold (0.63 log units) above, within the range that was stated.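

In this assay, for the compounds shown here, compound 3 has no single value, so no step to compound 4 can be read, even with compound 4 at 699 nM in hand. The compounds shown leave open how the change from hydroxymethyl to 2-aminoethyl alters the inhibition constant. No further data are available here to explain the result for compound 4.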